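From pyridin-4-yl to 4-methylphenyl on the shared core

The source may report more compounds than this note shows. Statements on the series, on what has been measured and on what is new or still open speak of the compounds shown alone.

In an ADME assay on H9c2 cells (Rattus norvegicus) for cytotoxicity, read by resazurin assay, with a stated time of 72 h (a higher number here means that more compound is tolerated, a lower number that less compound is tolerated), compound 1 (`C/C(=N\Nc1nc(-c2ccccn2)cs1)c1ccc(Cl)c(Cl)c1`) gives 10200 nM, and compound 2 (`C/C(=N\Nc1nc(-c2ccncc2)cs1)c1ccc(Cl)c(Cl)c1`) gives 41900 nM, the higher of the two numbers. Compound 3 (`C/C(=N\Nc1nc(-c2ccc(C)cc2)cs1)c1ccc(Cl)c(Cl)c1`) carries 4-methylphenyl in place of pyridin-4-yl on an aromatic carbon. Among the compounds with values here, one measured step bears on this change: a 4.1-fold higher number from compound 1 to compound 2 (0.61 log units; beyond the scatter), which swapped the pyridinyl attachment at the same place. Within the data shown here, no measured compound has a ring of carbon only there, so a similarly modest move toward a lower number is expected in this assay. The expected change is a 2.1-fold lower number from compound 2 to compound 3 (0.32 log units; beyond the scatter). For compound 3 the estimated value is 20000 nM, with an expected range of 7000 nM to 55000 nM.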

Compound 3, half-maximal cytotoxic concentration: > 50000 nM
Compound 3: a limit, no number (the forecaster's own chance of this, stated with the estimate: 10%); at least 2.5-fold (0.39 log units) between middle value and limit.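

In this assay compound 3 gives > 50000 nM, which is a limit of the assay and not a number. The change to 4-methylphenyl reads an at least 1.1-fold higher number from compound 2 to compound 3 (0.07 log units; that floor lies within the scatter), and measured against pyridin-2-yl it reads an at least 4.9-fold higher number from compound 1 to compound 3 (0.69 log units; beyond the scatter). So this place on the shared core, where only pyridinyl rings had been seen, also takes a six-membered aromatic ring of carbon only without a lower number than compound 2 shows. As far as these compounds go, how far compound 3 lies past its limit stays open, so its order relative to compound 2 is unsettled. Also open, from the compounds shown here alone, is how an amine or a carboxylic acid in place of the methyl on that ring would read.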